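The compounds below may be only part of what the source reports. "The series", "measured", "known", "first", "only" and "open" are said of these compounds alone.

In a functional assay on DU-145 cells (Homo sapiens) for inhibition, read by trypan blue exclusion, with a stated time of 96 h (on this read-out higher numbers stand for weaker inhibition of growth and lower numbers for stronger inhibition of growth), compound 1 `CCOc1cc(/C=C(\C(=O)c2ccc(Cl)cc2)S(=O)(=O)Cc2ccc(Cl)cc2)ccc1O` gives 10000 nM, compound 2 `COc1ccccc1/C=C(\C(=O)c1ccc(Cl)cc1)S(=O)(=O)Cc1ccc(Cl)cc1` gives 25000 nM and compound 3 `Cc1cc(C)cc(/C=C(\C(=O)c2ccc(Cl)cc2)S(=O)(=O)Cc2ccc(Cl)cc2)c1` gives 1000 nM, the lowest of these three numbers. Compound 4 `Cc1cc(C)cc(/C=C(\C(=O)c2ccc(Cl)cc2)S(=O)(=O)c2ccc(Br)cc2)c1` keeps the 3,5-dimethylphenyl group of compound 3 but differs at another place: 4-bromophenyl in place of 4-chlorobenzyl on a sulfonyl sulfur, with 4-bromophenyl in place of 4-chlorobenzyl on a sulfonyl sulfur. The measured steps, a 2.5-fold higher number from compound 1 to compound 2 (0.40 log units; beyond the scatter), a 10-fold lower number from compound 1 to compound 3 (1.00 log units; beyond the scatter) and a 25-fold lower number from compound 2 to compound 3 (1.40 log units; beyond the scatter), ranging from modest to large, all change the group on the double-bonded chain carbon, so none tests this change. Going by the values given here, no measured step supports a shift beyond the scatter in either direction. In this assay the estimated step is a 1.5-fold higher number from compound 3 to compound 4 (0.18 log units; within the scatter). The expected value for compound 4 is 1500 nM, with an estimated range of 250 nM to 10000 nM.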

Compound 4, concentration for 50% growth inhibition: 10000 nM
For compound 4 the middle estimate is 6.7-fold (0.82 log units) below the measured one; the measured number falls inside the stated range.
By their numbers in this assay, from the lowest: compound 3; then compounds 1 and 4 (each within the scatter of the next); then compound 2.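

In this assay, going by these compounds alone, the sulfonyl sulfur position proves sensitive for the first time: with the 3,5-dimethylphenyl group held constant, 4-bromophenyl in place of 4-chlorobenzyl gives a 10-fold higher number from compound 3 to compound 4 (1.00 log units; beyond the scatter). Growth inhibition is therefore weaker with this change, so the group on the sulfonyl sulfur also shapes the read-out, not only the group on the double-bonded chain carbon. Nothing at hand explains the shift. Within the data shown here, the single step changes both the halogen and the benzyl-to-phenyl attachment, so their separate contributions remain unresolved. A 4-bromobenzyl or 4-chlorophenyl group on the sulfonyl sulfur would separate them.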